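Phenylethenyl for methoxyphenyl: expected read-out of compound 4

The source may hold more compounds than are shown below. What is called first, only, known or untested is meant among the compounds shown, and "the series" means these compounds.

Measured compounds in a functional assay on MCF7 cells (Homo sapiens) for cytotoxicity, read by MTT assay, with a stated time of 2 days, tested at 0.1 uM; on this read-out lower numbers stand for a stronger effect and higher numbers for a weaker effect at the one concentration tested:
compound 1, `CC(=O)c1cc(-c2ccc(F)cc2)cc2cc(-c3ccc(F)cc3)[nH]c12`, gives 99.8%
compound 2, `COc1ccc(-c2cc(C(C)=O)c3[nH]c(-c4ccc(F)cc4)cc3c2)cc1`, gives 88.4%
compound 3, `COc1ccc(-c2cc(C(C)=O)c3[nH]c(-c4ccc(OC)cc4)cc3c2)cc1`, gives 96.5%

Compound 2 holds the lowest of the three numbers in this assay. Its nearest neighbour is compound 3, reached by a number 8.1 percentage points higher from compound 2 to compound 3 (within the scatter), a step within the scatter; the step of a number 11.4 percentage points lower from compound 1 to compound 2 (beyond the scatter) is the only one beyond the scatter, and it is modest.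

Compound 4, `CC(=O)c1cc(/C=C/c2ccccc2)cc2cc(-c3ccc(F)cc3)[nH]c12`, is not yet measured. It differs from compound 2 in one place: 2-phenylethenyl in place of 4-methoxyphenyl on an aromatic carbon.

Neither measured step bears directly on this change. Both of them, a number 11.4 percentage points lower from compound 1 to compound 2 (beyond the scatter) and a number 8.1 percentage points higher from compound 2 to compound 3 (within the scatter), exchange methoxy for fluoro on an aromatic carbon, and both are small. Going by the values given here, nothing among the measured compounds tests the exchange of an aryl group for an alkenyl group at this position. All three numbers sit high and close together, so the expectation for compound 4 is a step of no more than modest size, in no preferred direction, a number 1.6 percentage points higher from compound 2 to compound 4 (within the scatter). Compound 4 is therefore estimated at 90%, within a range from 70% to 102%.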

Compound 4, a percentage reported as activity, at one concentration (the size of the read-out at that concentration, not a potency): 98.4%
The estimate for compound 4 lay 8.4 percentage points below the measured number; measured number inside the range.
By their numbers in this assay, from the lowest: compounds 2, 3, 4 and 1 (each within the scatter of the next, the first and the last beyond it).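

At the aromatic carbon meta to an acetyl group, a group other than a directly attached substituted phenyl now has a reading in this assay: 2-phenylethenyl gives a number 10 percentage points higher from compound 2 to compound 4 (within the scatter) in place of 4-methoxyphenyl, and a number 1.4 percentage points lower from compound 1 to compound 4 (within the scatter) in place of 4-fluorophenyl. Compound 4 therefore cannot be told apart from either compound 1 or compound 2 on this read-out, although the step between those two, a number 11.4 percentage points lower from compound 1 to compound 2 (beyond the scatter), lies beyond the scatter. No measurement at hand accounts for this result.

Going by these compounds, all four compounds read high at the one concentration tested, so it remains open whether any group at this position can shift the read-out substantially. On these data alone, how an amine, a carboxylic acid or the saturated 2-phenylethyl group would read here also remains open.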